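Bromophenyl and trifluoromethylphenyl variants on a thiazolylhydrazone core

The compounds below may be only part of what the source reports. "The series", "measured", "known", "first", "only" and "open" are said of these compounds alone.

Measured so far in a functional assay on A549 cells (Homo sapiens) for inhibition, read by MTT assay, with a stated time of 48 h; a lower number here means a stronger inhibitor, a higher number a weaker inhibitor:
- compound 1, `COc1cc(/C=N/Nc2nc(-c3cccc(Br)c3)cs2)c(Br)c(Br)c1OC`: 37000 nM
- compound 2, `COc1cc(/C=N/Nc2nc(-c3ccc(C(F)(F)F)cc3)cs2)c(Br)c(Br)c1OC`: 17600 nM

Among the compounds with values here, compound 2 gives the lowest of the two numbers in this assay; compound 1 is its only neighbour, and the step of a 2.1-fold lower number from compound 1 to compound 2 (0.32 log units; beyond the scatter) is modest but beyond the scatter.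

Compound 3, `COc1cc(/C=N/Nc2nc(-c3ccc(Br)cc3)cs2)c(Br)c(Br)c1OC`, is not yet measured. Its difference from compound 2 is bromo in place of trifluoromethyl on an aromatic carbon; cut one bond further out, the change reads 4-(trifluoromethyl)phenyl to 4-bromophenyl.

Within the data shown here, no measured step swaps these two groups at the same position. Among the measured compounds shown here, the only step available, a 2.1-fold lower number from compound 1 to compound 2 (0.32 log units; beyond the scatter), moves a bromo from one position to a trifluoromethyl at another, so it bears on compound 3 only indirectly. Compound 3 keeps the bromo of compound 1 and the position of compound 2, so a number between the two is expected, most likely within the scatter of compound 2, i.e. a step of a 1.4-fold higher number from compound 2 to compound 3 (0.15 log units; within the scatter) is expected.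

Compound 3 is estimated at 25000 nM in this assay, within 10000 nM to 60000 nM.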

Compound 3, half-maximal inhibitory concentration: 46100 nM
For compound 3 the middle estimate is 1.8-fold (0.27 log units) below the measured one, and the stated range covers the measured number.
By their numbers in this assay, from the lowest: compound 2; then compounds 1 and 3 (each within the scatter of the next).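

In this assay, the exchange at this position can now be read directly: a 2.6-fold higher number from compound 2 to compound 3 (0.42 log units; beyond the scatter), so bromo does not stand in for trifluoromethyl at the place para to a large group. Moving the bromo gives a 1.2-fold higher number from compound 1 to compound 3 (0.10 log units; within the scatter), so 4-bromophenyl and 3-bromophenyl cannot be separated here, and among the three compounds only the trifluoromethyl of compound 2 sets a number apart. Nothing accompanying these numbers bears on why the two groups differ.

Open, going by these compounds, is how an amine or a carboxylic acid at the same place on the phenyl ring would read in this assay. The compounds shown also leave open whether the step seen with trifluoromethyl would persist if the two bromo groups shared by all three compounds were replaced.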